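A Smaller Ring in Place of Piperidine

The source may hold more compounds than are shown below. What is called first, only, known or untested is meant among the compounds shown, and "the series" means these compounds.

Of the compounds shown here, three have been measured in an assay on HEK-293T cells for inhibition of phospholipase A and acyltransferase 4 (Homo sapiens), with stated times of 30 min and 20 min; on this read-out higher numbers stand for weaker inhibition and lower numbers for stronger inhibition. Compound 1 `O=C(CCc1ccc(Cl)cc1)C(=O)NCCCCc1ccccc1` gives 1580 nM in this assay. Compound 2 `CCOC(=O)C(F)(F)C(O)CCc1ccccc1` returns only a limit of the assay, > 10000 nM, in this assay. Compound 3 `O=C(CCc1ccc(Cl)cc1)C(=O)N1CCCCC1` likewise returns only a limit, > 10000 nM, in this assay. Compound 3 therefore stands at the limit of > 10000 nM in this assay, at which 2 of the 3 values shown sit, so no number is known for it. Compound 4 `O=C(CCc1ccc(Cl)cc1)C(=O)N1CCCC1` differs from compound 3 by one change: pyrrolidin-1-yl in place of piperidin-1-yl on a carbonyl carbon. For the measured compounds named here, no measured pair shows what such a ring change does in this assay, so no step size can be drawn from the data. Compound 4 is expected to stay close to the limit, with an expected step that the limit leaves unreadable from compound 3 to compound 4 not beyond the scatter. The estimate for compound 4 in this assay is 15000 nM, between 5000 nM and 50000 nM.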

Compound 4, half-maximal inhibitory concentration: > 10000 nM
Compound 4 gave a limit, no number (the forecaster's own chance of this, stated with the estimate: 75%); the middle value does not contradict the limit.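

Compound 3 and compound 4 both return only a limit in this assay, so no step can be read between them. Still open, going by these compounds, is how pyrrolidin-1-yl and piperidin-1-yl truly compare, since neither compound has a measured number.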